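The compounds below may be only part of what the source reports. "The series", "measured", "known", "first", "only" and "open" are said of these compounds alone.

Measured compounds in an ADME assay on microsomes from liver (Mus musculus, strain CD-1) for metabolic stability, read by LC-MS, using NADPH, with a stated time of 30 min, tested at 1 uM; on this read-out lower numbers stand for a less stable compound and higher numbers for a more stable compound:
compound 1, `CN(Cc1ccc2c(c1)OCCO2)c1cc(=O)c2cc(C(F)(F)F)cc([N+](=O)[O-])c2s1`, gives 6.46%
compound 2, `O=c1nc(N2CCN(CC3CCCCC3)CC2)sc2c([N+](=O)[O-])cc(C(F)(F)F)cc12`, gives 63.9%

Of these two numbers compound 1 stands lowest; compound 2 lies higher by a step beyond the usual scatter. Compound 3, `CN(Cc1ccccc1)c1cc(=O)c2cc(C(F)(F)F)cc([N+](=O)[O-])c2s1`, has not been measured. It differs from compound 1 in one place: phenyl in place of 2,3-dihydro-1,4-benzodioxin-6-yl on a saturated chain carbon bound to a nitrogen on an aromatic ring. For the measured compounds named here, no step between measured compounds isolates such a change, so the expectation is guided only by the low value of compound 1 itself. The step from compound 1 to compound 3 is expected to be a number 2.5 percentage points higher from compound 1 to compound 3 (within the scatter), within the scatter in either direction. Compound 3 is therefore estimated at 9%, with a range from 2% to 28%.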

Compound 3, percent of the compound remaining: 13%
For compound 3 the middle estimate is 4 percentage points below the measured one, within the range that was stated.
By their numbers in this assay, from the lowest: compounds 1 and 3 (each within the scatter of the next); then compound 2.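

In this assay, phenyl in place of 2,3-dihydro-1,4-benzodioxin-6-yl on a saturated chain carbon bound to a nitrogen on an aromatic ring gives a small step (a number 6.5 percentage points higher from compound 1 to compound 3 (within the scatter)). Compound 1 and compound 3 cannot be told apart here, so the non-aromatic ring with its two hetero atoms is not what sets the low number of compound 1. No other data speak to the reason for this result. Going by these compounds, whether a phenyl carrying a carboxylic acid or an amine at this place would read differently remains open.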